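The source may hold more compounds than are shown below. What is called first, only, known or untested is meant among the compounds shown, and "the series" means these compounds.

The measured compounds and their results in a functional assay on B16-F10 cells (Mus musculus) for inhibition, read by MTT assay, with a stated time of 48 h (a lower number here means a stronger inhibitor, a higher number a weaker inhibitor), are:
compound 1, `CCCCCCCCNC(=O)/C=C/c1c(/C=C/c2ccc(OC)cc2)cc(OC)cc1OC`, 8060 nM;
compound 2, `CCCCCN(CCCCC)C(=O)/C=C/c1c(/C=C/c2ccc(OC)cc2)cc(OC)cc1OC`, 9270 nM;
compound 3, `COc1ccc(/C=C/c2cc(OC)cc(OC)c2/C=C/C(=O)N2CCC(Cl)CC2)cc1`, 4690 nM.

All three share one core and differ only in the group on the carbonyl carbon. Compound 3 sits at the lower end of the three numbers, yet its separation from the others is small: the step of a 1.7-fold lower number from compound 1 to compound 3 (0.24 log units; within the scatter) and the step of a 2.0-fold lower number from compound 2 to compound 3 (0.30 log units; within the scatter) both stay inside the scatter, and the step of a 1.2-fold higher number from compound 1 to compound 2 (0.06 log units; within the scatter) between the other two is inside it as well. On this evidence the three amides cannot be told apart.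

Compound 4, `COc1ccc(/C=C/c2cc(OC)cc(OC)c2/C=C/C(=O)N2CCCC(C)C2)cc1`, has not yet been measured in this assay. It differs from compound 3 in one place: 3-methylpiperidin-1-yl in place of 4-chloropiperidin-1-yl on a carbonyl carbon. Among the measured compounds shown here, the steps that bear on this change are the two earlier exchanges at the same carbonyl carbon, both of which moved the number by less than the scatter. For the measured compounds named here, since every change at that position so far has left the result essentially unchanged, no step beyond the scatter is expected here either, in either direction.

For compound 4 the expected value in this assay is 5000 nM, with a range from 2300 nM to 11000 nM. This estimate corresponds to an expected step of a 1.1-fold higher number from compound 3 to compound 4 (0.03 log units; within the scatter).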

Compound 4, half-maximal inhibitory concentration: 8250 nM
The estimate for compound 4 lay 1.7-fold (0.22 log units) below the measured number; the range from low to high includes it.
By their numbers in this assay, from the lowest: compounds 3, 1, 4 and 2 (each within the scatter of the next).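

Exchanging the ring substituent itself, with 4-chloropiperidin-1-yl leaving and 3-methylpiperidin-1-yl entering on the carbonyl carbon, gives a 1.8-fold higher number from compound 3 to compound 4 (0.25 log units; within the scatter) in this assay, so a change confined to a six-membered ring of the same heavy-atom count also stays inside the scatter. Compound 4 also cannot be separated from the two open-chain amides, as shown by a 1.1-fold lower number from compound 2 to compound 4 (0.05 log units; within the scatter) and by a 1.0-fold higher number from compound 1 to compound 4 (0.01 log units; within the scatter), which means that the ring amide bearing a methyl group reads the same as both the dipentylamino and the octylamino amides. Across these four compounds, then, the group on the carbonyl carbon has varied in ring, chain and substituent without any step leaving the scatter, and nothing available here bears on the reason for this flat result.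

On these data alone, what stays open is whether a group of another kind at this carbonyl carbon, such as morpholin-4-yl, a piperazine or a carboxylic acid on the ring, would produce a step beyond the scatter. The compounds shown also leave open whether the plain piperidin-1-yl amide, 4-methylpiperidin-1-yl or 3-chloropiperidin-1-yl would read any differently, since only those would separate the identity of the ring substituent from its place.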